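Swapping tert-butyl for cyclopropylmethyl on compound 2

This account rests on a few compounds, and the source may have more. Where it says the series, first, only, none or still open, it means among the compounds named here.

In a functional assay on a cell-free system (plasma, Homo sapiens), with a stated time of 3 min (on this read-out higher numbers stand for weaker inhibition and lower numbers for stronger inhibition), the measured compounds read as follows
Compound 1 `CC(C)(C)OC[C@@H](O)C(=O)N1[C@H](C(=O)NCc2cc(Cl)ccc2-n2cnnn2)C[C@@H]2C[C@@H]21` gives 500 nM
Compound 2 `CC(C)(C)[C@@H](O)C(=O)N1C[C@@H]2C[C@@H]2[C@H]1C(=O)NCc1cc(Cl)ccc1-n1cnnn1` gives 570 nM
Compound 3 `CC(C)(C)[C@@H](O)C(=O)N1C[C@H]2C[C@H]2[C@H]1C(=O)NCc1cc(Cl)ccc1-n1cnnn1` gives 1200 nM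

Compound 2 and compound 1 lie within the scatter of each other, so neither can be ranked above the other. Among the compounds with values here, the only measured step from compound 2 is modest (a 2.1-fold higher number from compound 2 to compound 3 (0.32 log units; beyond the scatter)). Compound 4 `O=C(NCc1cc(Cl)ccc1-n1cnnn1)[C@@H]1[C@H]2C[C@H]2CN1C(=O)[C@H](O)CC1CC1`, not yet measured, carries cyclopropylmethyl in place of tert-butyl on a saturated chain carbon bound to a carbonyl carbon and an oxygen on a saturated carbon. Within the data shown here, the measured step rests on the fact that compounds 2 and 3 differ only in the configuration as drawn and no measured step exchanges these two groups, so it serves only as a rough gauge of size. On that gauge, a change in this assay no larger than that modest step is expected, toward a higher number. The estimated change is small (a 1.6-fold higher number from compound 2 to compound 4 (0.20 log units; within the scatter)). Compound 4 is expected at 900 nM (estimated range 300 nM to 2700 nM).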

Compound 4, half-maximal inhibitory concentration: 1400 nM
Compound 4: middle estimate off by 1.6-fold (0.19 log units), on the low side, within the range that was stated.
By their numbers in this assay, from the lowest: compounds 1 and 2 (each within the scatter of the next); then compounds 3 and 4 (each within the scatter of the next).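

In this assay, within the data shown here, the exchange of tert-butyl for cyclopropylmethyl gives a 2.5-fold higher number from compound 2 to compound 4 (0.39 log units; beyond the scatter), the first measured step at this saturated chain carbon; the earlier step concerned only configuration at saturated ring carbons. The two groups match in heavy atoms, hydrogen-bond donors, hydrogen-bond acceptors and net charge, and the entering group differs in carrying a three-membered ring, so matching these counts did not keep the number within the scatter at this position. Nothing measured here gives a cause for this step.

The compounds shown leave open how an amine, a carboxylic acid or a longer chain would read on this carbon, and whether any group there gives a lower number than tert-butyl. They also leave open whether the same exchange would give a step of similar size on the core of compound 3.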